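The source may hold more compounds than are shown below. What is called first, only, known or untested is meant among the compounds shown, and "the series" means these compounds.

- Compound 1 `CCOC(=O)N1N=C(c2ccccc2)CC1c1cc(OC)c(OC)c(OC)c1`: 8920 nM
- Compound 2 `CCCOC(=O)N1N=C(c2ccccc2)CC1c1cc(OC)c(OC)c(OC)c1`: > 10000 nM, a limit
- Compound 3 `CCOC(=O)N1N=C(c2cccc(OC)c2)CC1c1cc(OC)c(OC)c(OC)c1`: not yet measured

Within the data shown here, in a functional assay on HT-29 cells (Homo sapiens) for antiproliferative activity, read by MTT assay, with a stated time of 48 h (a higher number here means a weaker inhibitor of growth, a lower number a stronger inhibitor of growth), compound 1 gives 8920 nM, the only exact number so far. Compound 3 carries one change, methoxy in place of hydrogen on an aromatic carbon, turning phenyl to 3-methoxyphenyl. Among the measured compounds shown here, the one measured step, an at least 1.1-fold higher number from compound 1 to compound 2 (0.04 log units; that floor lies within the scatter), lies at another place in the molecule and offers only weak guidance. No step beyond the scatter, in either direction, is therefore expected. The estimate is an expected 1.3-fold lower number from compound 1 to compound 3 (0.11 log units; within the scatter). Compound 3 is expected at 7000 nM, with an estimated range of 2000 nM to 14000 nM.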

Compound 3, concentration for 50% growth inhibition: 7860 nM
Beside the measured number, compound 3's estimate is 1.1-fold (0.05 log units) below it, within the range that was stated.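

In this assay, methoxy in place of hydrogen on an aromatic carbon, meta to a large group, gives a 1.1-fold lower number from compound 1 to compound 3 (0.05 log units; within the scatter). This is the first exact step shown and the first at the phenyl group, and it shows that turning phenyl to 3-methoxyphenyl does not move the number beyond the scatter. On these data alone, whether an amine or a hydroxyl group at this place would do so stays open. The value of compound 2 is a limit and not a number, so the step to it gives no exact size: the limit of > 10000 nM in this assay, at which 1 of the 3 values shown sits.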